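The compounds below may be only part of what the source reports. "The series", "measured", "known", "first", "only" and "open" are said of these compounds alone.

Measured so far:
compound 1, `COc1ccc(/C=C\c2cc(OC)c(OC)c(OC)c2)cc1OCc1ccc(C=O)cc1`: 4200 nM
compound 2, `COc1ccc(/C=C\c2cc(OC)c(OC)c(OC)c2)cc1OCc1ccc(CO)cc1`: 6600 nM

In a functional assay on B16-F10 cells (Mus musculus) for antiproliferative activity, read by CCK-8 assay, with a stated time of 48 h (a lower number here means a stronger inhibitor, a higher number a weaker inhibitor), compound 1 gives 4200 nM and compound 2 gives 6600 nM. Going by the values given here, compound 2 holds the higher of the two numbers, but its only neighbour is compound 1 and the step of a 1.6-fold higher number from compound 1 to compound 2 (0.20 log units; within the scatter) does not separate the two.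

Compound 3, `COc1ccc(/C=C\c2cc(OC)c(OC)c(OC)c2)cc1OCc1ccc(CN2CC[C@@H](C(=O)O)C2)cc1`, is the next member. Against compound 2 the change is 3-carboxypyrrolidin-1-yl in place of hydroxy on a saturated chain carbon bound to an aromatic carbon. Among the compounds with values here, the single measured step, which installed the hydroxymethyl that compound 3 now extends, was a 1.6-fold higher number from compound 1 to compound 2 (0.20 log units; within the scatter); nothing measured shows what 3-carboxypyrrolidin-1-yl does, so that step bears on the question only by showing that the last change at this part of the molecule stayed small.

With no guide beyond that, compound 3 is expected to show a step of a 1.4-fold higher number from compound 2 to compound 3 (0.13 log units; within the scatter), with no confidence that it will clear the scatter in either direction. Compound 3 is therefore estimated at 9000 nM, with a range from 2500 nM to 30000 nM.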

Compound 3, half-maximal inhibitory concentration: > 10000 nM
Compound 3: no number, only a limit; the forecaster's own chance of this, stated with the estimate: 10%; middle value at least 1.1-fold (0.04 log units) away from the limit.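

In this assay compound 3 reads > 10000 nM, which is a limit of the assay and not a number. Taken against the hydroxymethyl compound, the reading gives only a floor, an at least 1.5-fold higher number from compound 2 to compound 3 (0.18 log units; that floor lies within the scatter), so the pair alone does not size the exchange of hydroxy for 3-carboxypyrrolidin-1-yl on this saturated chain carbon bound to an aromatic carbon. Going by these compounds alone, the reading against the formyl compound is firmer, an at least 2.3-fold higher number from compound 1 to compound 3 (0.37 log units; beyond the scatter), and this is the first change at this position to clear the scatter, in the direction of a weaker inhibitor.

From the compounds shown here alone, how far the true value of compound 3 lies past the limit remains unknown, as does whether the shift in the number belongs to the carboxylic acid, the pyrrolidine ring or the defined stereocentre. A methyl ester of the acid, a pyrrolidine without the carboxyl group, the opposite stereoisomer or an open-chain amine on the same carbon would each separate these parts, provided the value falls inside the measurable range of this assay.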